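Moving a Chloro Group on the Hydrazide Benzoyl Ring

The source may hold more compounds than are shown below. What is called first, only, known or untested is meant among the compounds shown, and "the series" means these compounds.

Three compounds sharing the core of compound 1 `CC(C)(C)N(NC(=O)c1ccccc1)C(=O)c1ccccc1Cl` have been tested in an assay on cells for agonist activity at ecdysone receptor (Bombyx mori), read by a luciferase reporter, with a stated time of 24 h; on this read-out lower numbers stand for an effect already at smaller amounts and higher numbers for an effect only at larger amounts of compound. Compound 1 gives 75.9 nM. Compound 2 `CC(C)(C)N(NC(=O)c1ccccc1Br)C(=O)c1ccccc1Cl` gives 316 nM, and compound 3 `CC(C)(C)N(NC(=O)c1cccc(Cl)c1)C(=O)c1ccccc1Cl` gives 155 nM. Among the three, compound 3 stands second highest: a 2.0-fold lower number from compound 2 to compound 3 (0.31 log units; beyond the scatter), while a 2.0-fold higher number from compound 1 to compound 3 (0.31 log units; beyond the scatter).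

Compound 4 `CC(C)(C)N(NC(=O)c1ccc(Cl)cc1)C(=O)c1ccccc1Cl` has not yet been measured. It differs from compound 3 by 4-chlorophenyl in place of 3-chlorophenyl on a carbonyl carbon. Going by the values given here, no measured step moves a chlorine from one ring position to another, so the expectation must rest on looser parallels. The steps of a 4.2-fold higher number from compound 1 to compound 2 (0.62 log units; beyond the scatter) and a 2.0-fold higher number from compound 1 to compound 3 (0.31 log units; beyond the scatter) show that placing a halogen on this ring raised the number in both cases, and the step of a 2.0-fold lower number from compound 2 to compound 3 (0.31 log units; beyond the scatter) shows that where the halogen sits shifts the number at a modest scale. The chlorine is kept in compound 4 and only its position changes, so the number is expected to stay in the same region as that of compound 3, with a 1.6-fold lower number from compound 3 to compound 4 (0.19 log units; within the scatter) as the estimated step. The estimate for compound 4 in this assay is 100 nM, within a range from 30 nM to 400 nM.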

Compound 4, half-maximal effective concentration: 115 nM
Compound 4: middle estimate off by 1.2-fold (0.06 log units), on the low side; low and high end bracket the measured number.
By their numbers in this assay, from the lowest: compounds 1, 4 and 3 (each within the scatter of the next, the first and the last beyond it); then compound 2.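

In this assay, exchanging 3-chlorophenyl for 4-chlorophenyl on a carbonyl carbon gives a 1.3-fold lower number from compound 3 to compound 4 (0.13 log units; within the scatter), so these two placements of the chlorine cannot be told apart on this read-out. Going by these compounds alone, the chlorine in the 4-chlorophenyl group also stays close to the unsubstituted phenyl, at a 1.5-fold higher number from compound 1 to compound 4 (0.18 log units; within the scatter), whereas the step to the 3-chlorophenyl group is printed as just beyond the scatter, at a 2.0-fold higher number from compound 1 to compound 3 (0.31 log units; beyond the scatter); thus a halogen on this ring does not raise the number clearly in every case, as the earlier steps alone had suggested. The 2-bromophenyl group remains apart from the 4-chlorophenyl group, with a 2.7-fold lower number from compound 2 to compound 4 (0.44 log units; beyond the scatter), and compound 2 now has steps beyond the scatter to each of the other three compounds.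

The compounds shown leave open whether a methoxy group or an amine in place of the chlorine of the 4-chlorophenyl group would stay in this same narrow region or leave it. Nothing available here bears on why the number responds to these changes as it does.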